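This account rests on a few compounds, and the source may have more. Where it says the series, first, only, none or still open, it means among the compounds named here.

Compound 1, `COc1ccc(-c2cc(/C=C/C(=O)c3ccc(N)cc3)[nH]n2)cc1`, in a functional assay on NCI-H460 cells (Homo sapiens) for cytotoxicity, read by sulforhodamine B assay, with a stated time of 48 h, tested at 100 uM (a higher number here means a weaker effect of the compound at the concentration tested, a lower number a stronger effect), gives -70%.
Compound 2, `COc1ccc(-c2cc(/C=C/C(=O)c3ccc(N)cc3)[nH]n2)cc1OC`, in this assay gives -76%.
Compound 3, `COc1cc(C(=O)/C=C/c2cc(-c3cc(OC)c(OC)c(OC)c3)n[nH]2)cc(OC)c1OC`, in this assay gives -55%.

Compounds 1 and 2 share one core, compound 3 another; the difference between the two cores is not broken down here. Within the first core, a single change carries compound 2 to compound 1: hydrogen in place of methoxy on an aromatic carbon. This change made a step of a number 6 percentage points higher from compound 2 to compound 1 (within the scatter), so the two values cannot be ordered against each other. Compound 3 stands apart from both: its number is beyond the scatter from compound 1 and further still from compound 2.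

Compound 4, `COc1ccc(-c2cc(/C=C/C(=O)c3cc(OC)c(OC)c(OC)c3)[nH]n2)cc1OC`, has not been measured in this assay. It is obtained from compound 3 by hydrogen in place of methoxy on an aromatic carbon. For the measured compounds named here, this is the same kind of change as the one from compound 2 to compound 1, though the surroundings differ: in compound 3 the carbon that loses its methoxy is also meta to a methoxy group, which is not so in compound 2. Going by the values given here, the earlier step of this kind stayed within the scatter, and there is only that one example to lean on.

The expectation for compound 4 in this assay is therefore a value close to that of compound 3, the expected step being a number 5 percentage points higher from compound 3 to compound 4 (within the scatter), resting on the step of a number 6 percentage points higher from compound 2 to compound 1 (within the scatter). The estimate for compound 4 is -50%, expected to lie between -68% and -32%.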

Compound 4, a percentage reported as activity, at one concentration (the size of the read-out at that concentration, not a potency): -60%
Estimate against measurement, compound 4: 10 percentage points above; the range from low to high includes it.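

In this assay, hydrogen in place of methoxy on an aromatic carbon made a step of a number 5 percentage points lower from compound 3 to compound 4 (within the scatter), so these two values cannot be ordered against each other. Set beside the earlier step, the change reads the same on both cores, and the two steps cannot be told apart: the same change on two cores in this assay, a number 6 percentage points higher (within the scatter) from compound 2 to compound 1 and a number 5 percentage points lower (within the scatter) from compound 3 to compound 4, 11 percentage points apart, within the scatter of two such steps This shows that on the two cores at hand the change left the read-out within the scatter, and that the opposite directions of the two steps carry no weight; it does not show that the change is without effect in general, as it rests on only two pairs, each read at one concentration in one cell line.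

Left open is whether the same change at other places on these aromatic rings, or the loss of more than one methoxy group, would also stay within the scatter. Going by these compounds, it also remains open whether a hydroxyl group, a fluorine atom or a longer chain such as ethoxy, put in the place of that methoxy, would leave the read-out as little moved as hydrogen did.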